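The compounds below may be only part of what the source reports. "The series", "measured", "known", "first", "only" and "open" are said of these compounds alone.

In a functional assay on A2780 cells (Homo sapiens) for antiproliferative activity, read by MTT assay, with a stated time of 48 h (on this read-out higher numbers stand for weaker inhibition and lower numbers for stronger inhibition), compound 3 `CNCC(=O)Nc1cc(OC)ccc1C(=O)c1ccc2c(c1)C=CC(C)(C)O2` gives 850 nM, which lies within the scatter of both other measured compounds: compound 1 `COc1ccc(C(=O)c2ccc(OC)c3c2OC(C)(C)C=C3)c(NC(=O)CBr)c1` at 980 nM and compound 2 `COc1ccc(C(=O)c2ccc3c(c2)C=CC(C)(C)O3)c(NC(=O)CN)c1` at 590 nM. Compound 4 `COc1ccc(C(=O)c2ccc3c(c2)C=CC(C)(C)O3)c(NC(=O)CN(C)C)c1` differs from compound 3 by methyl in place of hydrogen on an amine nitrogen, turning methylamino into dimethylamino. Among the compounds with values here, the one measured step that bears on this change is the same replacement of hydrogen by methyl on an amine nitrogen, a 1.4-fold higher number from compound 2 to compound 3 (0.16 log units; within the scatter), and it stays within the scatter. No step beyond the scatter is therefore expected in this assay, only a possible slight drift towards a higher number. The expected step is a 1.1-fold higher number from compound 3 to compound 4 (0.05 log units; within the scatter). For compound 4 the estimated value is 950 nM, with an expected range of 480 nM to 1900 nM.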

Compound 4, half-maximal inhibitory concentration: 1020 nM
For compound 4 the middle estimate is 1.1-fold (0.03 log units) below the measured one; the measured number falls inside the stated range.
By their numbers in this assay, from the lowest: compounds 2, 3, 1 and 4 (each within the scatter of the next).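

In this assay, adding a second methyl on the amine nitrogen gives a 1.2-fold higher number from compound 3 to compound 4 (0.08 log units; within the scatter) and the full replacement of amino by dimethylamino gives a 1.7-fold higher number from compound 2 to compound 4 (0.24 log units; within the scatter) and both steps stay within the scatter. Amino, methylamino and dimethylamino on this saturated chain carbon are therefore not told apart by this read-out, even across the two methyl additions taken together. No supporting measurement is available to explain these small steps.

Going by these compounds, whether diethylamino, a longer chain or a carboxylic acid in place of the amine would give a step beyond the scatter remains open.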